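This account rests on a few compounds, and the source may have more. Where it says the series, first, only, none or still open, it means among the compounds named here.

Working notes on the series. In an assay on isolated protein for inhibition of high affinity 3',5'-cyclic-AMP phosphodiesterase 7A (Homo sapiens), read by cAMP accumulation, with a stated time of 20 min (a lower number here means a stronger inhibitor, a higher number a weaker inhibitor), compound 1 `CCCCCn1c(-c2ccco2)nc2c(N)ccnc21` gives only a limit, > 200000 nM. The reading of compound 1 is the limit of > 200000 nM in this assay, at which 1 of the 3 values shown sits, so it is an assay limit and not a number. Compound 2 `COCCNc1ccnc2c1nc(-c1ccco1)n2C1CCCC1` gives 119000 nM in this assay. Compound 3 `COCCNc1nccc2c1nc(-c1ccco1)n2C1CCCC1` gives 192000 nM in this assay; the numbers of compound 2 and compound 3 lie within the usual scatter of one another, so no order is read between them, and compound 3 is simply one of the two numbers shown.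

Compound 4 `COCCCNc1nccc2c1nc(-c1ccco1)n2C1CCCC1` differs from compound 3 by methoxymethyl in place of methoxy on a saturated chain carbon, two bonds along the chain from a nitrogen on an aromatic ring. Within the data shown here, no measured pair shows this change, and the two numbers available differ only within the scatter, so nothing measured here points in either direction. The step from compound 3 to compound 4 in this assay is expected to be none beyond the scatter, a 1.0-fold lower number from compound 3 to compound 4 (0.00 log units; within the scatter). Compound 4 is therefore expected to give about 190000 nM in this assay, within a range from 80000 nM to 400000 nM, with a real chance that this assay again reports only a limit.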

Compound 4, half-maximal inhibitory concentration: 142000 nM
The estimate for compound 4 lay 1.3-fold (0.13 log units) above the measured number, within the range that was stated.
By their numbers in this assay, from the lowest: compounds 2, 4 and 3 (each within the scatter of the next). At a limit, above all of these: compound 1.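

In this assay, among these compounds, the change from (2-methoxyethyl)amino to (3-methoxypropyl)amino gives the first step that can be read between two compounds differing in one place, a 1.4-fold lower number from compound 3 to compound 4 (0.13 log units; within the scatter), so at this position the added chain carbon produces no change beyond the scatter. Compound 4 also gives a number and not an assay limit, which leaves the 3-methoxypropyl chain within the readable part of this assay. Compound 1 remains the one assay limit in the series: the limit of > 200000 nM in this assay, at which 1 of the 4 values shown sits.

From the compounds shown here alone, whether a longer chain, or a chain ending in an amine or a carboxylic acid in place of the methoxy group, would move the number beyond the scatter stays open. No step shown establishes a group at this position that lowers or raises the number beyond the scatter.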